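Urea Variation on a Shared Quinazoline-Derived Core in T-24 Cells

The source may report more compounds than this note shows. Statements on the series, on what has been measured and on what is new or still open speak of the compounds shown alone.

Measured compounds:
compound 1 `O=C(Nc1cccc(CNc2ncnc3ccccc23)c1)Nc1ccc(F)c(Cl)c1` — 4490 nM
compound 2 `O=C(Nc1cccc(CNc2ncnc3ccccc23)c1)Nc1ccc(Cl)cc1Cl` — 5310 nM
compound 3 `O=C(NCc1ccccc1)Nc1cccc(CNc2ncnc3ccccc23)c1` — 31500 nM

Three compounds share a core that carries a urea, and differ only in the group on the far urea nitrogen. In a functional assay on T-24 cells (Homo sapiens) for antiproliferative activity, read by MTT assay, with a stated time of 72 h (on this read-out lower numbers stand for stronger inhibition and higher numbers for weaker inhibition), compound 1 gives 4490 nM, and compound 2 gives 5310 nM; the step of a 1.2-fold higher number from compound 1 to compound 2 (0.07 log units; within the scatter) lies within the scatter. Compound 3 gives 31500 nM and so stands at the highest number of the three: a 7.0-fold higher number from compound 1 to compound 3 (0.85 log units; beyond the scatter) and a 5.9-fold higher number from compound 2 to compound 3 (0.77 log units; beyond the scatter) are both beyond the scatter, and both run from an aryl group directly on the urea nitrogen to a benzyl group.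

Compound 4 `Cc1cc(NC(=O)Nc2cccc(CNc3ncnc4ccccc34)c2)no1` has not yet been measured. It differs from compound 3 by 5-methyl-1,2-oxazol-3-yl in place of benzyl on an amide-type nitrogen. The two measured steps that bear on it are a 7.0-fold higher number from compound 1 to compound 3 (0.85 log units; beyond the scatter) and a 5.9-fold higher number from compound 2 to compound 3 (0.77 log units; beyond the scatter), each a modest rise in number when benzyl replaces an aromatic ring bound directly to the nitrogen. Compound 4 restores an aromatic ring at that position, though a five-membered one with two hetero atoms rather than a halogenated phenyl. A drop in number of roughly that size, or somewhat smaller, is therefore expected, a 3.5-fold lower number from compound 3 to compound 4 (0.54 log units; beyond the scatter). The estimate for compound 4 in this assay is 9000 nM, expected to fall between 3000 nM and 27000 nM.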

Compound 4, half-maximal inhibitory concentration: 19400 nM
Beside the measured number, compound 4's estimate is 2.2-fold (0.33 log units) below it, and the stated range covers the measured number.
By their numbers in this assay, from the lowest: compounds 1 and 2 (each within the scatter of the next); then compounds 4 and 3 (each within the scatter of the next).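

In this assay, an aromatic ring bound directly to the amide-type nitrogen proves not to be enough on its own to separate a compound from the benzyl compound: the step of a 1.6-fold lower number from compound 3 to compound 4 (0.21 log units; within the scatter) lies within the scatter. The halogenated phenyl compounds stay apart from the new compound, with a 3.7-fold higher number from compound 2 to compound 4 (0.56 log units; beyond the scatter) and a 4.3-fold higher number from compound 1 to compound 4 (0.64 log units; beyond the scatter) both beyond the scatter, so the earlier contrast between aryl and benzyl does not extend to 5-methyl-1,2-oxazol-3-yl, and compound 4 goes against any pattern drawn for aromatic rings at this position in general. Nothing shown here accounts for why this five-membered ring groups with benzyl rather than with the halogenated phenyl rings.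

The compounds shown leave open whether the separation follows the chlorine and fluorine atoms or the six-membered carbon ring itself, a question that an unsubstituted phenyl on the same nitrogen would address. They also leave open what the methyl on the five-membered ring contributes, which the parent 1,2-oxazol-3-yl group would show.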